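Extending the amide substituent of compound 3 with a flexible linker

This account rests on a few compounds, and the source may have more. Where it says the series, first, only, none or still open, it means among the compounds named here.

Measured so far:
Compound 1, `CCSC(=S)SCC(=O)c1ccc(NC(=O)c2cnc3ccccc3c2)cc1`: 119 nM
Compound 2, `CCOC(=O)SCC(=O)c1ccc(OC)cc1`: 5360 nM
Compound 3, `CCSC(=S)SCC(=O)c1ccc(C(=O)Nc2ccccc2)cc1`: 521 nM

Of the compounds shown here, three have been measured in an assay on HEK293 cells for inhibition of protein deacetylase HDAC6 (Homo sapiens); a higher number here means a weaker inhibitor, a lower number a stronger inhibitor. Compound 3 gives 521 nM, which places it second highest of the three numbers. Its nearest neighbour is compound 1, whose value of 119 nM is lower by a margin beyond the scatter, and its furthest is compound 2, whose value of 5360 nM is higher by a margin also beyond the scatter. So compound 3 sits between the two, closer to the stronger inhibitor.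

The next compound keeps the whole of compound 3 and alters only the group on the amide nitrogen. Compound 4, `CCSC(=S)SCC(=O)c1ccc(C(=O)NCCOc2ccccc2)cc1`, carries 2-phenoxyethyl in place of phenyl on an amide-type nitrogen. Within the data shown here, no pair among the measured compounds differs in this single place, so there is no measured step to lean on; what is known is only the three values above and the nature of the change.

Because compound 3 gives 521 nM, the expectation for compound 4 is a value in the same region, with a step of a 1.3-fold lower number from compound 3 to compound 4 (0.11 log units; within the scatter) that may well lie within the scatter. Compound 4 is therefore estimated at 400 nM, with a range from 120 nM to 1500 nM.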

Compound 4, half-maximal inhibitory concentration: 483 nM
Beside the measured number, compound 4's estimate is 1.2-fold (0.08 log units) below it, within the range that was stated.
By their numbers in this assay, from the lowest: compound 1; then compounds 4 and 3 (each within the scatter of the next); then compound 2.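

Among these compounds, this is the first measured pair that differs in one place only, so it gives the first direct reading of the group on the amide-type nitrogen. In this assay, placing 2-phenoxyethyl where phenyl stood gives a 1.1-fold lower number from compound 3 to compound 4 (0.03 log units; within the scatter), so the two compounds cannot be told apart, even though the new group has 9 heavy atoms against 6 and brings a hydrogen-bond acceptor that phenyl lacks. This position therefore accepts a chain and an oxygen between the amide nitrogen and the aromatic ring with no measurable penalty or gain, though no measurement shown here explains this result.

A single step cannot show how far this tolerance extends, for instance whether benzyl, with a shorter chain, or 3-phenoxypropyl, with a longer chain, would give a number in the same region. It also leaves open whether an amine or a carboxylic acid at the end of the chain, or a substituent such as chlorine on the phenoxy ring, would move the number beyond the scatter in either direction.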